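From methyl to trifluoromethyl on the shared core

The source may report more compounds than this note shows. Statements on the series, on what has been measured and on what is new or still open speak of the compounds shown alone.

Measured in an ADME assay on microsomes from liver (Homo sapiens) for metabolic stability (a higher number here means faster removal of the compound, a lower number slower removal), so far
Compound 1 `Cc1ccc([C@H](C)NC(=O)Cn2nnc3ccccc3c2=O)cc1` gives < 9.9 mL/min/kg (a limit of the assay)
Compound 2 `Cc1ccc([C@H](C)NC(=O)Cn2nnc3ccc(C)cc3c2=O)cc1` gives 179 mL/min/kg (a number)

Going by the values given here, compound 2 at 179 mL/min/kg holds the only actual number so far. The entry for compound 1 is a limit of the assay. The measured step of an at least 18-fold higher number from compound 1 to compound 2 (1.25 log units; beyond the scatter) is large and beyond the scatter, and it came with methyl in place of hydrogen on an aromatic carbon.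

Compound 3 `Cc1ccc([C@H](C)NC(=O)Cn2nnc3ccc(C(F)(F)F)cc3c2=O)cc1` alters that same spot, with the difference trifluoromethyl in place of methyl on an aromatic carbon being trifluoromethyl in place of methyl on an aromatic carbon. Among the compounds with values here, only that one step bears on this change, and no measurement yet covers trifluoromethyl. Since the methyl that went with the rise now leaves, a sizeable step to a lower number is expected in this assay with wide uncertainty. The expected change is a 4.5-fold lower number from compound 2 to compound 3 (0.65 log units; beyond the scatter) in this estimate. Compound 3 is estimated at 40 mL/min/kg with an expected range of 10 mL/min/kg to 150 mL/min/kg in this measurement.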

Compound 3, clearance: 435 mL/min/kg
The estimate for compound 3 lay 11-fold (1.04 log units) below the measured number, and the stated range ends below it.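

In this assay, trifluoromethyl in place of methyl gave a 2.4-fold higher number from compound 2 to compound 3 (0.39 log units; beyond the scatter), so the number did not fall back when the methyl left but rose further. Trifluoromethyl in place of hydrogen on this aromatic carbon gave an at least 43-fold higher number from compound 1 to compound 3 (1.64 log units; beyond the scatter), which shows that the large rise seen earlier is not tied to methyl alone, since both groups shown here go with a far higher number than hydrogen. The entry for compound 1 is a limit of the assay: the limit of < 9.9 mL/min/kg in this assay, at which 1 of the 3 values shown sits.

Only hydrogen, methyl and trifluoromethyl are shown at this carbon, so it remains open whether a single fluorine, a methoxy group or a nitrile there would also go with a high number. On these data alone, it also remains open whether the same groups would act alike on other aromatic carbons of the shared core.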